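Ethynyl in place of 1-benzofuran-2-yl on the shared core

A few compounds are considered here, and "the series" means these few. Any claim that something is new, unique, unknown or untested is made for them only; others in the source may bear on it.

In a functional assay on CEM-DNR-bulk cells (Homo sapiens), read by MTT assay, with a stated time of 72 h (on this read-out lower numbers stand for stronger inhibition and higher numbers for weaker inhibition), compound 1 `CNc1ncnc2c1c(-c1ccco1)cn2[C@@H]1O[C@H](CO)[C@@H](O)[C@H]1O` gives > 20000 nM, a limit of the assay. Compound 2 `CNc1ncnc2c1c(-c1cccs1)cn2[C@@H]1O[C@H](CO)[C@@H](O)[C@H]1O` gives > 20000 nM, also a limit. Compound 3 `CNc1ncnc2c1c(-c1cc3ccccc3o1)cn2[C@@H]1O[C@H](CO)[C@@H](O)[C@H]1O` gives > 20000 nM, again a limit. Going by the values given here, the series so far stands at the limit of > 20000 nM in this assay, at which 3 of the 3 values shown sit, and compound 3 has no numeric position within it.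

The next change leads to compound 4 `C#Cc1cn([C@@H]2O[C@H](CO)[C@@H](O)[C@H]2O)c2ncnc(NC)c12`: ethynyl in place of 1-benzofuran-2-yl on an aromatic carbon. In words, this is ethynyl in place of 1-benzofuran-2-yl on an aromatic carbon.

The measured steps that bear on it are those among the aromatic groups: a step that the two limits leave unreadable from compound 1 to compound 2, a step that the two limits leave unreadable from compound 1 to compound 3 and a step that the two limits leave unreadable from compound 2 to compound 3. None has a readable size, and none involves ethynyl, so they offer only weak guidance. In this assay, any readable change is expected toward stronger inhibition, with its size highly uncertain, and a further limit remains likely. The expected step is an at least 1.6-fold lower number from compound 3 to compound 4 (0.22 log units; that floor lies within the scatter). For compound 4 the estimated value is 12000 nM, with an expected range from 2000 nM to 40000 nM.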

Compound 4, half-maximal inhibitory concentration: 18500 nM
The estimate for compound 4 lay 1.5-fold (0.19 log units) below the measured number, within the range that was stated.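

In this assay, going by these compounds alone, compound 4 gives 18500 nM, the first number rather than a limit, so this aromatic carbon can carry ethynyl, a group with no ring, and still yield a readable value. On these data alone, the replacement can be read only as floors: an at least 1.0-fold lower number from compound 3 to compound 4 (0.03 log units; that floor lies within the scatter), an at least 1.0-fold lower number from compound 2 to compound 4 (0.03 log units; that floor lies within the scatter) and an at least 1.0-fold lower number from compound 1 to compound 4 (0.03 log units; that floor lies within the scatter); none of these shows that ethynyl strengthens inhibition relative to the three ring groups, whose true values remain unknown. The series still sits largely at one edge of the read-out: the limit of > 20000 nM in this assay, at which 3 of the 4 values shown sit.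

As far as these compounds go, it remains open whether another small group at this carbon, such as a nitrile, an amine or a longer alkynyl chain, gives a number further from that limit. Also open, from the compounds shown here alone, is whether the ethynyl result holds with changes elsewhere on the shared core.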